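Diethoxymethyl in Place of Carboxyethyl Across Two Cores

The compounds below may be only part of what the source reports. "The series", "measured", "known", "first", "only" and "open" are said of these compounds alone.

Compound 1 `CC(C)=CCC[C@H](C)c1ccc(C)c2c1OCN(CCCCC(=O)O)C2` was tested in a functional assay on MDA-MB-231 cells (Homo sapiens) for inhibition, read by MTT assay, with a stated time of 72 h; on this read-out lower numbers stand for stronger inhibition and higher numbers for weaker inhibition. In this test compound 1 gives only a limit, > 50000 nM. Compound 3 `CCOC(CCN1COc2c([C@@H](C)CCC=C(C)C)ccc(C)c2C1)OCC` keeps the core of compound 1 and differs from it by diethoxymethyl in place of 2-carboxyethyl on a saturated chain carbon, two bonds along the chain from an amine nitrogen in a ring. In this assay compound 3 gives 11300 nM. The step between them is an at least 4.4-fold lower number from compound 1 to compound 3 (0.64 log units; beyond the scatter); because compound 1 sits at the limit of > 50000 nM in this assay, at which 2 of the 3 values shown sit, the size of this step is known only as a lower bound.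

Compound 2 `CC(C)=CCC[C@H](C)c1ccc(C)c(CNCCCCC(=O)O)c1O` rests on another core, and how the cores of compound 1 and compound 2 differ is not broken down here. In this assay compound 2 also gives only a limit, > 50000 nM.

Compound 4 `CCOC(CCNCc1c(C)ccc([C@@H](C)CCC=C(C)C)c1O)OCC` has not yet been measured. It differs from compound 2 by diethoxymethyl in place of 2-carboxyethyl on a saturated chain carbon, two bonds along the chain from an amine nitrogen. This is the same kind of change as that from compound 1 to compound 3, though the place is not identical: in the first pair the amine nitrogen is in a ring, whereas in compound 2 and compound 4 it is not.

For compound 4 a step of an at least 3.3-fold lower number from compound 2 to compound 4 (0.52 log units; beyond the scatter) is expected, set beside an at least 4.4-fold lower number from compound 1 to compound 3 (0.64 log units; beyond the scatter) and resting on the value that compound 3 gives, 11300 nM, on the core of compound 1. Compound 4 is therefore estimated at 15000 nM, expected to fall between 5000 nM and 50000 nM.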

Compound 4, half-maximal inhibitory concentration: 14900 nM
For compound 4 the middle estimate is 1.0-fold (0.00 log units) above the measured one; low and high end bracket the measured number.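

In this assay the replacement of 2-carboxyethyl by diethoxymethyl also gives a lower number on the second core, with an at least 3.3-fold lower number from compound 2 to compound 4 (0.52 log units; beyond the scatter), so the change points the same way in both pairs: the same change on two cores in this assay, an at least 4.4-fold lower number (0.64 log units; beyond the scatter) from compound 1 to compound 3 and an at least 3.3-fold lower number (0.52 log units; beyond the scatter) from compound 2 to compound 4; the limit leaves it open whether they differ. What the two pairs do not give is the true size of the change on either core, since each step starts from a compound that gives only a limit: the limit of > 50000 nM in this assay, at which 2 of the 4 values shown sit. The direction of the change therefore carried from the core of compound 1 to the core of compound 2, but this rests on just two pairs and shows neither that the size of the step is the same on both cores nor that the direction would hold on any further core.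

The compounds shown leave open whether the lower numbers come from the loss of the carboxylic acid or from the arrival of the two ethoxy groups, as a simple ester of the acid or an aldehyde at the chain end does not appear among them. On these data alone, it also remains open how far the result depends on chain length, as diethoxymethyl is seen on only one chain, and a longer or shorter chain carrying it does not appear here.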